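The source may hold more compounds than are shown below. What is called first, only, known or untested is meant among the compounds shown, and "the series" means these compounds.

Of the compounds shown here, three in this set have been measured in an assay on isolated protein for inhibition of Amine oxidase [flavin-containing] A (Homo sapiens), read by fluorescence, with a stated time of 15 min; a lower number here means a stronger inhibitor, a higher number a weaker inhibitor. Compound 1, `O=C1CCc2ccc(OCc3cccc(Br)c3)cc2N1`, gives 49200 nM. Compound 2, `O=C1OCc2cc(OCc3ccc(C(F)(F)F)cc3)ccc21`, gives 9240 nM. Compound 3, `O=C1OCc2cc(OCc3ccc(Cl)cc3)ccc21`, gives 3610 nM, the lowest of the three numbers. Among the compounds with values here, the one single-point step among them is a 2.6-fold lower number from compound 2 to compound 3 (0.41 log units; beyond the scatter), so swapping the trifluoromethyl for a chloro made a modest difference.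

Compound 4, `O=C1OCc2cc(OCc3ccc(F)cc3)ccc21`, differs from compound 3 by fluoro in place of chloro on an aromatic carbon. Within the data shown here, no measured pair here exchanges one halogen for another, so the chloro-to-trifluoromethyl step is the only comparison that bears on it, and it only shows that a change at this same position moved the number modestly. On that basis, compound 4 is expected to stay close to compound 3, with the estimated step of a 1.7-fold higher number from compound 3 to compound 4 (0.22 log units; within the scatter) pointing toward a slightly higher number, but not far beyond the scatter. Compound 4 is therefore estimated at 6000 nM, with a range from 2500 nM to 15000 nM.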

Compound 4, half-maximal inhibitory concentration: 1330 nM
Beside the measured number, compound 4's estimate is 4.5-fold (0.65 log units) above it; measured number below the stated range.
By their numbers in this assay, from the lowest: compound 4; then compound 3; then compound 2; then compound 1.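

In this assay, the swap of chloro for fluoro on this aromatic carbon, para to a large group, gives a 2.7-fold lower number from compound 3 to compound 4 (0.43 log units; beyond the scatter), so exchanging one halogen for another matters here about as much as the earlier change from trifluoromethyl to chloro. Replacing trifluoromethyl with fluoro gives the larger change, a 6.9-fold lower number from compound 2 to compound 4 (0.84 log units; beyond the scatter), and across these three compounds the number falls in the order trifluoromethyl, chloro, fluoro, with none going against that order. No measurement shown here explains why the number falls in this order.

On these data alone, it remains open how a methoxy group, a nitrile or a plain hydrogen at this place would compare, and whether the same order holds at another carbon of this ring. Compound 1 differs from these compounds in more than one place, so it cannot show whether the order holds on its core.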